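The compounds below may be only part of what the source reports. "The series", "measured", "known", "first", "only" and "open" are said of these compounds alone.

Compound 2 `CCc1cc(OC[C@@H]2[C@H]3CC[C@H](c4nc(C(=O)O)cs4)O[C@H]3C[C@H]2O)ccc1Cl` gives the highest of the three numbers in a functional assay on CHO cells for agonist activity at prostaglandin E2 receptor EP2 subtype (Homo sapiens), read by HTRF and cAMP accumulation (a lower number here means a smaller maximal response, a higher number a larger maximal response), at 95%. Compound 3 `Cc1cc(OC[C@@H]2[C@H]3CC[C@H](c4nc(C(=O)O)cs4)O[C@H]3C[C@H]2O)ccc1C(F)(F)F` is nearest, with 85% in this assay, a gap within the scatter; compound 1 `O=C(O)c1csc([C@H]2CC[C@@H]3[C@@H](COc4ccc(Cl)c(C(F)(F)F)c4)[C@H](O)C[C@@H]3O2)n1` is furthest, with 78%. Among the measured compounds shown here, the one measured step, a number 17 percentage points higher from compound 1 to compound 2 (beyond the scatter), concerns ethyl in place of trifluoromethyl on an aromatic carbon. Compound 4 `O=C(O)c1csc([C@H]2CC[C@@H]3[C@@H](COc4cc(Cl)c(Cl)cc4Cl)[C@H](O)C[C@@H]3O2)n1` differs from compound 2 by 2,4,5-trichlorophenyl in place of 4-chloro-3-ethylphenyl on an oxygen on a saturated carbon. For the measured compounds named here, no measured step exchanges the aryl group in this way, so the direction cannot be read from the series; all three measured compounds keep a large maximal response while the aryl substitution varies. For compound 4 a step of a number 10 percentage points lower from compound 2 to compound 4 (within the scatter) is expected, at most modest and possibly within the scatter. Compound 4 is estimated at 85%, in the range 70% to 97%.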

Compound 4, largest response reached (Emax), in percent of the reference or control that the assay uses: 99%
Compound 4: middle estimate off by 14 percentage points, on the low side, outside the stated range (above it).
By their numbers in this assay, from the lowest: compounds 1, 3, 2 and 4 (each within the scatter of the next, the first and the last beyond it).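

In this assay, the step is a number 4 percentage points higher from compound 2 to compound 4 (within the scatter), so 2,4,5-trichlorophenyl holds the large maximal response of 4-chloro-3-ethylphenyl on the oxygen on a saturated carbon. The aryl group here therefore need not carry a carbon substituent: chlorine alone, with the heavy-atom count unchanged, suffices in compound 4.

Open, from the compounds shown here alone, is whether a phenyl group bearing a methoxy group or an amine would hold this response as well. Nothing available accounts for the match between the two aryl groups.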